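The source may report more compounds than this note shows. Statements on the series, on what has been measured and on what is new or still open speak of the compounds shown alone.

In a functional assay on the whole organism (plasma, strain Wistar) with Rattus norvegicus as the target, with a stated time of 15 days, at a dose of 30 mg/kg by the oral route (a higher number here means a stronger effect of the compound at the dose given, a lower number a weaker effect), compound 3 `O=C1NC(=O)/C(=C/c2ccc(OCCSc3nnc(-c4ccccc4)o3)cc2)S1` gives 16.1%. Among the three measured compounds this is the second highest number. Compound 1 `O=C1NC(=O)/C(=C/c2ccc(OCCSc3nnc(-c4ccccc4)[nH]3)cc2)S1` gives 14.7%, which lies within the usual scatter of the number for compound 3, so the two cannot be told apart. Compound 2 `COc1ccc(-c2nnc(SCCOc3ccc(/C=C4\SC(=O)NC4=O)cc3)[nH]2)cc1` gives 40%, a number that sits beyond the scatter above that of compound 3. Among the measured compounds shown here, the one measured step that changes a single place is a number 25.3 percentage points higher from compound 1 to compound 2 (beyond the scatter); it concerns a methoxy group and not the part of the molecule now in question. Compound 4 `O=C1NC(=O)/C(=C/c2ccc(OCCSc3nnc(-c4cccnc4)o3)cc2)S1` differs from compound 3 by pyridin-3-yl in place of phenyl on an aromatic carbon. For the measured compounds named here, no measured pair shows this exchange, so there is no direct guide to its size or direction, and the methoxy step from compound 1 to compound 2 does not carry over to it. The expectation is therefore no step beyond the scatter, a number 0.9 percentage points higher from compound 3 to compound 4 (within the scatter). Compound 4 is estimated at 17%, with a range from 5% to 32%.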

Compound 4, a percentage reported as activity, at one dose (the size of the read-out at that dose, not a potency): 39.3%
Compound 4: middle estimate off by 22.3 percentage points, on the low side, and the stated range ends below it.
By their numbers in this assay, from the lowest: compounds 1 and 3 (each within the scatter of the next); then compounds 4 and 2 (each within the scatter of the next).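

Putting pyridin-3-yl in place of phenyl at this position gives a number 23.2 percentage points higher from compound 3 to compound 4 (beyond the scatter) in this assay, so this ring is not a neutral spot where such an exchange leaves the read-out unchanged. The change is small on paper: the ring keeps its 6 heavy atoms, one carbon gives way to one nitrogen, and the count of hydrogen-bond acceptors goes from 0 to 1. Nothing measured here says why the number rises with this exchange.

Going by these compounds, it remains open whether pyridin-4-yl or pyridin-2-yl would give a similar rise, or whether the rise belongs to pyridin-3-yl alone. On these data alone, it is also open whether the same exchange would raise the number on the core of compound 1, or whether an amine on the phenyl ring could do the same.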